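Fluoro for chloro on two inactive pyrazole cores

The source may report more compounds than this note shows. Statements on the series, on what has been measured and on what is new or still open speak of the compounds shown alone.

Compound 1 `Clc1ccc(-c2n[nH]cc2N2CCCNCC2)cc1` and compound 2 `Fc1ccc(-c2n[nH]cc2N2CCCNCC2)cc1` share one core. In an assay on isolated protein for binding affinity to 5-hydroxytryptamine receptor 4 (Homo sapiens) (on this read-out lower numbers stand for stronger inhibition and higher numbers for weaker inhibition), compound 1 gives > 10000 nM, which is a limit of the assay rather than a number. In this assay compound 2 likewise reaches only the limit > 10000 nM. The change between them is fluoro in place of chloro on an aromatic carbon, and its step is a step that the two limits leave unreadable from compound 1 to compound 2 because of the limit of > 10000 nM in this assay, at which 3 of the 3 values shown sit. Compound 3 `Clc1ccccc1-c1n[nH]cc1N1CCNCC1` has another core; how the two cores differ is not broken down here. In this assay compound 3 also stops at the limit > 10000 nM. Compound 4 `Fc1ccccc1-c1n[nH]cc1N1CCNCC1` is not yet measured; it differs from compound 3 by fluoro in place of chloro on an aromatic carbon, the same kind of change as before, though placed ortho to a large group rather than para to a large group. With one unreadable example and compound 3 at the limit, compound 4 is expected to show a step that the limit leaves unreadable from compound 3 to compound 4 and to land near 20000 nM, probably again as a limit, somewhere between 5000 nM and 80000 nM.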

Compound 4, inhibition constant: > 10000 nM
Compound 4 ended at the assay's limit; the forecaster's own chance of this, stated with the estimate: 80%; the middle value is on the limit's open side.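

Among these compounds, the step from compound 3 to compound 4 cannot be read, and no new step comes from this result: the limit of > 10000 nM in this assay, at which 4 of the 4 values shown sit. The compounds shown leave open whether fluoro in place of chloro changes anything in this assay; none gives a readable number.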